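This account rests on a few compounds, and the source may have more. Where it says the series, first, only, none or still open, it means among the compounds named here.

Among the measured compounds shown here, compound 1 `CC(C)C(c1ccc(-c2ccc3cccc(F)c3c2)[nH]c1=O)N1CCCCC1=O` gives 23500 nM in a physicochemical assay for solubility, measured as kinetic solubility, at pH 2 (a higher number here means a more soluble compound, a lower number a less soluble compound), the second highest of the three numbers known. Compound 3 `CC(C)C(c1noc(=O)[nH]1)c1ccc(-c2ccc3cccc(F)c3c2)[nH]c1=O` gives 23200 nM, and the change is a 1.0-fold lower number from compound 1 to compound 3 (0.01 log units; within the scatter). Compound 2 `CC(C)C(Nc1nccs1)c1ccc(-c2ccc3cccc(F)c3c2)[nH]c1=O` gives 32900 nM, with a 1.4-fold higher number from compound 1 to compound 2 (0.15 log units; within the scatter). Between compound 2 and compound 3 the step is a 1.4-fold lower number from compound 2 to compound 3 (0.15 log units; within the scatter). Compound 4 `Cc1c[nH]c(C(c2ccc(-c3ccc4cccc(F)c4c3)[nH]c2=O)C(C)C)n1` is not yet measured; it differs from compound 1 in one place: 4-methyl-1H-imidazol-2-yl in place of 2-oxopiperidin-1-yl on a saturated chain carbon bound to an aromatic carbon and a saturated chain carbon. All three known steps at the same place, each swapping one five- or six-membered group for another, stay within the scatter, so for 4-methyl-1H-imidazol-2-yl in place of 2-oxopiperidin-1-yl no step beyond the scatter is expected in this assay. Compound 4 is accordingly estimated at 27000 nM, range 12000 nM to 60000 nM, meaning an expected 1.1-fold higher number from compound 1 to compound 4 (0.06 log units; within the scatter).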

Compound 4, solubility: 6300 nM
Beside the measured number, compound 4's estimate is 4.3-fold (0.63 log units) above it, and the stated range ends above it.
By their numbers in this assay, from the lowest: compound 4; then compounds 3, 1 and 2 (each within the scatter of the next).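

At the saturated chain carbon, this assay now shows steps beyond the scatter: a 3.7-fold lower number from compound 1 to compound 4 (0.57 log units; beyond the scatter) and a 3.7-fold lower number from compound 3 to compound 4 (0.57 log units; beyond the scatter) and a 5.2-fold lower number from compound 2 to compound 4 (0.72 log units; beyond the scatter). This position is therefore not indifferent to its group, and 4-methyl-1H-imidazol-2-yl sets compound 4 apart from the three groups that stayed within the scatter of one another. No measurement shown accounts for this separation. On these data alone, whether the step follows the methyl or the imidazole ring remains open, as an unsubstituted 1H-imidazol-2-yl would be needed to separate them. As far as these compounds go, how a primary amine or a carboxylic acid on this carbon would compare also remains open.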